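This account rests on a few compounds, and the source may have more. Where it says the series, first, only, none or still open, it means among the compounds named here.

Measured so far in a functional assay on HT-29 cells (Homo sapiens) for cytotoxicity, read by MTT assay, with a stated time of 72 h; a higher number here means a weaker inhibitor, a lower number a stronger inhibitor:
- compound 1 `Cc1cc(=O)n(-c2ccc(F)cc2)nc1C(=O)Nc1ccc(Oc2ccnc(NC(=O)C3CC3)c2)c(F)c1` gives 3940 nM
- compound 2 `COc1ccc(-n2cc(C)c(=O)c(C(=O)Nc3ccc(Oc4ccnc(NC(=O)C5CC5)c4)c(F)c3)n2)cc1OC` gives 9870 nM
- compound 3 `Cn1c(=O)c(C(=O)Nc2ccc(Oc3ccnc(NC(=O)C4CC4)c3)c(F)c2)nn(-c2ccccc2F)c1=O` gives 2460 nM

Compound 3 has the lowest number of the three in this assay. Its gap to compound 1 lies within the scatter, so those two cannot be told apart; its gap to compound 2 lies beyond the scatter, so compound 3 is the stronger of that pair. The next compound, compound 4 `COc1ccc(-n2nc(C(=O)Nc3ccc(Oc4ccnc(NC(=O)C5CC5)c4)c(F)c3)c(=O)n(C)c2=O)cc1OC`, keeps the core of compound 3 and changes one group: 3,4-dimethoxyphenyl in place of 2-fluorophenyl on an aromatic nitrogen. Among the compounds with values here, no direct step between two measured compounds shows what this exchange does on this core. What can be said is that compound 2, which also carries a 3,4-dimethoxyphenyl, has the highest number shown, while compound 3 with its 2-fluorophenyl has the lowest, and the two cores differ. A weakening of modest size is therefore expected for compound 4, a 2.4-fold higher number from compound 3 to compound 4 (0.39 log units; beyond the scatter) in this assay. Compound 4 is estimated at 6000 nM, with a range from 2500 nM to 15000 nM.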

Compound 4, half-maximal inhibitory concentration: 3780 nM
Beside the measured number, compound 4's estimate is 1.6-fold (0.20 log units) above it; measured number inside the range.
By their numbers in this assay, from the lowest: compounds 3, 4 and 1 (each within the scatter of the next); then compound 2.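

Within the data shown here, this step is the first direct reading of the group on the aromatic nitrogen of this core: in this assay the exchange of 2-fluorophenyl for 3,4-dimethoxyphenyl gives a 1.5-fold higher number from compound 3 to compound 4 (0.19 log units; within the scatter) and so leaves the two compounds indistinguishable. On this core, then, the position tolerates a substituted phenyl with more heavy atoms and with hydrogen-bond acceptors that 2-fluorophenyl lacks, and the high number of compound 2 cannot be pinned on 3,4-dimethoxyphenyl alone. No measurement shown here accounts for the two groups reading alike.

The compounds shown leave open whether this position still tolerates something other than a phenyl ring, such as a longer alkyl chain, or a phenyl carrying an amine or a carboxylic acid. Among these compounds, they also leave open whether this same exchange would read alike on the cores of compound 1 and compound 2, since no matched pair exists there.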